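Swapping Fluoro for Chloro on the Pendant Phenyl Ring

This account rests on a few compounds, and the source may have more. Where it says the series, first, only, none or still open, it means among the compounds named here.

Measured compounds:
Compound 1, `c1ccc([C@@H]2C[C@@H]3Cc4ccc5ccccc5c4N2O3)cc1`: 72900 nM
Compound 2, `Fc1ccc([C@@H]2C[C@@H]3Cc4ccc5ccccc5c4N2O3)cc1`: > 300000 nM

In an ADME assay on Vero cells (Chlorocebus sabaeus) for cytotoxicity, read by MTT assay, with a stated time of 72 h (a higher number here means that more compound is tolerated, a lower number that less compound is tolerated), compound 1 gives 72900 nM. For compound 2 the read-out is only a limit of the assay, > 300000 nM. Compound 2 thus stands at the limit of > 300000 nM in this assay, at which 1 of the 2 values shown sits, so its true value is not known, only that it lies beyond the range the assay covers. For the measured compounds named here, the single measured step, an at least 4.1-fold higher number from compound 1 to compound 2 (0.61 log units; beyond the scatter), is likewise open-ended.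

Compound 3, `Clc1ccc([C@@H]2C[C@@H]3Cc4ccc5ccccc5c4N2O3)cc1`, is not yet measured. It differs from compound 2 by chloro in place of fluoro on an aromatic carbon. Going by the values given here, only that one measured step bears on this change, and it shows that replacing hydrogen with a small halogen on this carbon pushed the number upward, out of range. Swapping one halogen for another at the same place is a smaller change, so compound 3 is expected to stay near where compound 2 stands, with an expected step of an at least 1.2-fold lower number from compound 2 to compound 3 (0.07 log units; that floor lies within the scatter) in this assay. Compound 3 is therefore estimated at 250000 nM, within 80000 nM to 700000 nM, and the assay may well again return only a limit.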

Compound 3, half-maximal cytotoxic concentration: 287000 nM
For compound 3 the middle estimate is 1.1-fold (0.06 log units) below the measured one; low and high end bracket the measured number.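

In this assay, for the compounds shown here, compound 3 gives the first in-range number for a halogen at this place on the pendant phenyl ring, so the gain over the unsubstituted ring now has a real size: a 3.9-fold higher number from compound 1 to compound 3 (0.60 log units; beyond the scatter). Chloro in place of hydrogen therefore moves the read-out beyond the scatter, in the same direction as fluoro does in compound 2. Chloro in place of fluoro reads an at least 1.0-fold lower number from compound 2 to compound 3 (0.01 log units; that floor lies within the scatter), and this cannot rank the two halogens because the fluoro compound gives only a limit: the limit of > 300000 nM in this assay, at which 1 of the 3 values shown sits.

Going by these compounds, the true value of compound 2 remains unknown, so how far the two halogens differ, if at all, stays open. The compounds shown also leave open whether the rise is special to halogens or would also appear with a methyl, a methoxy or an amine at this place.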